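A few compounds are considered here, and "the series" means these few. Any claim that something is new, unique, unknown or untested is made for them only; others in the source may bear on it.

Compound 3, with the structure `C=CCc1c(OC)nc2nc(C(=O)c3ccccc3)cn2c1C`, was tested in a functional assay on the whole organism with Rattus norvegicus as the target (on this read-out lower numbers stand for an effect already at smaller amounts and higher numbers for an effect only at larger amounts of compound), where compound 3 gives 5 mg/kg. Compound 1, `C=CCc1c(SC)nc2nc(C(=O)c3ccccc3)cn2c1C`, gives 5 mg/kg in this assay, and compound 2, `C=CCc1c(OC)nc2nc(C(=O)c3ccccc3)cn2c1CC`, gives 10 mg/kg. Compound 3 stands level with compound 1, and these two together show the smallest numbers of the three; the step of a 2.0-fold lower number from compound 2 to compound 3 (0.30 log units; within the scatter) and the step of no change at the digits printed from compound 1 to compound 3 (within the scatter) both stay within the scatter.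

Compound 4, `COc1nc2nc(C(=O)c3ccccc3)cn2c(C)c1OC`, has not yet been measured. It differs from compound 3 in one place: methoxy in place of allyl on an aromatic carbon. Among the measured compounds shown here, neither measured step touches this group or this kind of exchange, so no direct analogue exists among the measured compounds. What the measured steps do show is that small exchanges elsewhere on the shared core left the dose essentially unchanged. On that basis a modest shift at most is expected, with no preferred direction, and the step of a 1.4-fold higher number from compound 3 to compound 4 (0.15 log units; within the scatter) is estimated to stay within the scatter. Compound 4 is therefore expected to give about 7 mg/kg, with a range from 2.5 mg/kg to 20 mg/kg.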

Compound 4, minimum effective dose: 5 mg/kg
Compound 4: the middle estimate sits 1.4-fold (0.15 log units) above what was measured; measured number inside the range.
By their numbers in this assay, from the lowest: compounds 1, 3, 4 and 2 (each within the scatter of the next).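

Replacing allyl with methoxy on this aromatic carbon brings no change at the digits printed from compound 3 to compound 4 (within the scatter) in this assay. Among the compounds shown here, compounds 1, 2 and 3 all carry allyl here, so only this step shows that the allyl group, with its double bond outside the rings, can give way to methoxy, which brings a hydrogen-bond acceptor, without the minimum effective dose moving beyond the scatter. Nothing available explains why the dose holds across this exchange.

As far as these compounds go, whether the position tolerates any group or only these two stays open, as a plain hydrogen, an amine, a carboxylic acid or a longer chain such as hexyl could behave differently here. From the compounds shown here alone, it is also open whether methoxy would leave the dose within the scatter on a core carrying methylsulfanyl or ethyl at the other positions.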